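The compounds below may be only part of what the source reports. "The series", "measured", "known", "first", "only" and "open" are said of these compounds alone.

Compound 1 `CC(C)[C@H](NC(=O)c1cccc(Br)c1)C(=O)N1CCC[C@H]1C(=O)N[C@@H](CCCNC(=N)N)C(=O)CF`: 530 nM
Compound 2 `CC(C)[C@H](NC(=O)c1ccc(Cl)cc1)C(=O)N1CCC[C@H]1C(=O)N[C@@H](CCCNC(=N)N)C(=O)CF`: 1240 nM
Compound 3 `CC[C@H](C)[C@H](NC(=O)OCc1ccccc1)C(=O)N1CCC[C@H]1C(=O)N[C@@H](CCCNC(=N)N)C(=O)CF`: 2440 nM

All three values come from a functional assay on OCI-Ly3 cells (Homo sapiens) for inhibition, read by CellTiter-Glo, with stated times of 48 h and 96 h; a lower number here means a stronger inhibitor of growth, a higher number a weaker inhibitor of growth. Compound 3 lies within the scatter of compound 2, while compound 1 has a lower number than compound 3, beyond the scatter.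

The next compound is compound 4 `CC(C)(C)[C@H](NC(=O)OCc1ccccc1)C(=O)N1CCC[C@H]1C(=O)N[C@@H](CCCNC(=N)N)C(=O)CF`. Its change from compound 3 is tert-butyl in place of sec-butyl on a saturated chain carbon bound to an amide-type nitrogen and a carbonyl carbon, with the same atoms joined differently.

Among the measured compounds shown here, the only measured single-place step is a 2.3-fold higher number from compound 1 to compound 2 (0.37 log units; beyond the scatter), which is modest and concerns a different change, 4-chlorophenyl in place of 3-bromophenyl on a carbonyl carbon. It therefore gives only a rough idea of step size. For the measured compounds named here, no measured step involves the sec-butyl or tert-butyl group.

In this assay, no step beyond the scatter is expected, and neither direction is favoured. The expected step is a 1.1-fold higher number from compound 3 to compound 4 (0.03 log units; within the scatter).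

For compound 4 the estimated value is 2600 nM, with an expected range of 1100 nM to 6000 nM.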

Compound 4, concentration for 50% growth inhibition: 1440 nM
Compound 4: the middle estimate sits 1.8-fold (0.26 log units) above what was measured; the range from low to high includes it.
By their numbers in this assay, from the lowest: compound 1; then compounds 2, 4 and 3 (each within the scatter of the next).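

In this assay, tert-butyl in place of sec-butyl on the saturated chain carbon bound to an amide-type nitrogen and a carbonyl carbon gives a 1.7-fold lower number from compound 3 to compound 4 (0.23 log units; within the scatter). Among the compounds shown here, this is the first reading at this place, and it shows that rejoining the same four carbons, with the loss of the defined stereocentre of sec-butyl, does not shift growth inhibition beyond the scatter. No measured evidence accounts for the size of this step.

As far as these compounds go, whether this place also accepts a group of another kind, such as an amine, a carboxylic acid or a longer chain, remains open. Compound 3 and compound 4 differ from compound 1 and compound 2 in more than one place, so the contribution of each change to the gap between these pairs also remains unresolved.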